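The source may report more compounds than this note shows. Statements on the series, on what has been measured and on what is new or still open speak of the compounds shown alone.

This set rests on the shared core of compound 1 `CN[C@@H]1CCN(c2cc3c(cc2F)c(=O)c(C(=O)O)cn3Cc2ccc(-c3ccccc3)cc2)C1`, compound 2 `NCCNc1cc2c(cc1F)c(=O)c(C(=O)O)cn2Cc1ccc(-c2ccccc2)cc1` and compound 3 `NC[C@@H]1CCN(c2ccc3c(=O)c(C(=O)O)cn(Cc4ccc(-c5ccccc5)cc4)c3c2)C1`, each read in an assay on isolated protein for inhibition of DNA topoisomerase 1 (Homo sapiens), with a stated time of 15 min; on this read-out higher numbers stand for weaker inhibition and lower numbers for stronger inhibition. Compound 1 gives 34800 nM in this assay, compound 2 gives 72800 nM, and compound 3 gives 61200 nM. Among these three numbers, compound 3 stands second highest; its gap to compound 2 and its gap to compound 1 both lie within the scatter of repeated runs, so no order among the three can be claimed. Going by the values given here, the only step between compounds that differ in one place runs a 2.1-fold higher number from compound 1 to compound 2 (0.32 log units; beyond the scatter), where (2-aminoethyl)amino replaces 3-(methylamino)pyrrolidin-1-yl on an aromatic carbon.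

Compound 4 `NC[C@@H]1CCN(c2cc3c(cc2F)c(=O)c(C(=O)O)cn3Cc2ccc(-c3ccccc3)cc2)C1` differs from compound 3 in one place: fluoro in place of hydrogen on an aromatic carbon. Among the compounds with values here, none of the measured steps touches this change; the step from compound 1 to compound 2 alters a different group, and fluoro is present in both of them. Compound 1 and compound 2 already carry fluoro, and their numbers sit within the scatter of the number for compound 3. On that basis no step beyond the scatter is expected in this assay, and compound 4 is expected to sit a 1.1-fold lower number from compound 3 to compound 4 (0.05 log units; within the scatter) from compound 3. The estimate for compound 4 is 55000 nM, with a range from 25000 nM to 120000 nM.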

Compound 4, half-maximal inhibitory concentration: 15600 nM
For compound 4 the middle estimate is 3.5-fold (0.55 log units) above the measured one; the measured number lies below the stated range.
By their numbers in this assay, from the lowest: compound 4; then compounds 1, 3 and 2 (each within the scatter of the next, the first and the last beyond it).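

Swapping hydrogen for fluoro on this aromatic carbon, ortho to a 3-(aminomethyl)pyrrolidin-1-yl group, gives the first direct reading of this change: in this assay there is a 3.9-fold lower number from compound 3 to compound 4 (0.59 log units; beyond the scatter), a modest but real strengthening of inhibition. The earlier compounds shown here could not show this, since compound 1 and compound 2 both already carry fluoro and neither has a partner with hydrogen at that carbon. With fluoro held in place, the amine side group also counts: 3-(aminomethyl)pyrrolidin-1-yl in place of (2-aminoethyl)amino gives a 4.7-fold lower number from compound 2 to compound 4 (0.67 log units; beyond the scatter), and aminomethyl in place of methylamino on a saturated ring carbon gives a 2.2-fold lower number from compound 1 to compound 4 (0.35 log units; beyond the scatter), leaving compound 4 the strongest inhibitor of the four. Nothing at hand speaks to the reason for these steps.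

Going by these compounds alone, the fluoro step has been read with only one side group, so its size alongside the (2-aminoethyl)amino or 3-(methylamino)pyrrolidin-1-yl groups remains unknown. Going by these compounds, whether chloro or methoxy on the same aromatic carbon would shift the number as fluoro does also stays open.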